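This account rests on a few compounds, and the source may have more. Where it says the series, first, only, none or still open, it means among the compounds named here.

All four compounds share one core and an aromatic ring attached through a triple bond; they differ in that ring and in a methyl or cyclohexyl group. Compound 1 `CN1CCc2nc(C#Cc3cccnc3)ccc2C1=O` gave "not active" (no number reported) in a functional assay on HEK293 cells for positive allosteric modulation of metabotropic glutamate receptor 5 (Homo sapiens), read by FLIPR and calcium flux (a lower number here means that less compound is needed, a higher number that more compound is needed for the effect), so it contributes no number. Compound 2 `O=C1c2ccc(C#Cc3ccccc3)nc2CCN1C1CCCCC1` gives 40 nM in this assay, and compound 3 `Cc1cccc(C#Cc2ccc3c(n2)CCN(C2CCCCC2)C3=O)c1` gives 36 nM. Of the two numbers, compound 3 holds the lower, but the step of a 1.1-fold lower number from compound 2 to compound 3 (0.05 log units; within the scatter) lies within the usual scatter, so the two cannot be told apart on this evidence.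

Compound 4 `O=C1c2ccc(C#Cc3cccnc3)nc2CCN1C1CCCCC1` differs from compound 3 by pyridin-3-yl in place of 3-methylphenyl on a triple-bonded carbon. Among the measured compounds shown here, no measured step exchanges the aromatic ring itself; the only measured step, from compound 2 to compound 3, changed a methyl on that ring and stayed within the scatter. Compound 1 carries the same pyridin-3-yl group as compound 4 and differs from it only by a methyl in place of the cyclohexyl group, and compound 1 showed no activity, which advises caution without giving a number to build on. The estimated step of a 3.1-fold higher number from compound 3 to compound 4 (0.49 log units; beyond the scatter) is therefore a moderate rise in the amount needed. Compound 4 is expected to give 110 nM, within a range from 30 nM to 450 nM.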

Compound 4, half-maximal effective concentration: 387 nM
Beside the measured number, compound 4's estimate is 3.5-fold (0.55 log units) below it; measured number inside the range.
By their numbers in this assay, from the lowest: compounds 3 and 2 (each within the scatter of the next); then compound 4.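

In this assay, the aromatic ring on the triple-bonded carbon now proves sensitive to exchange: putting pyridin-3-yl in place of 3-methylphenyl gives an 11-fold higher number from compound 3 to compound 4 (1.03 log units; beyond the scatter) and putting it in place of phenyl gives a 9.7-fold higher number from compound 2 to compound 4 (0.99 log units; beyond the scatter) as the result. The earlier step on this ring, a 1.1-fold lower number from compound 2 to compound 3 (0.05 log units; within the scatter) when a methyl was added, showed only that this one small addition left no readable change, whereas the two new steps show that exchanging the carbon-only ring for one holding a nitrogen has a clear cost beyond the scatter. Compound 4 still gives a number while compound 1 gives "not active" (no number reported) with the same pyridin-3-yl, so this ring alone does not remove the effect when the cyclohexyl group is present, but no measurement here explains the cost of the exchange.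

As far as these compounds go, whether a chlorine or a methoxy group on the phenyl ring, or a thiophene ring in its place, would lower the number remains open. So does how the cyclohexyl group compares with a cyclopentyl group or a longer chain, since methyl is the only other group shown there.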